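This account rests on a few compounds, and the source may have more. Where it says the series, first, only, none or still open, it means among the compounds named here.

Compound 1 `CN1C/C(=C\c2ccc(Cl)cc2)C(=O)/C(=C/c2cccc([N+](=O)[O-])c2)C1`: > 20000 nM (a limit of the assay)
Compound 2 `CN1C/C(=C\c2ccc(Br)cc2)C(=O)/C(=C/c2cccc([N+](=O)[O-])c2)C1`: > 20000 nM (a limit of the assay)

In a functional assay on K562 cells (Homo sapiens) for cytotoxicity, read by MTT assay, with a stated time of 24 h (on this read-out higher numbers stand for weaker inhibition and lower numbers for stronger inhibition), compound 2 gives > 20000 nM, which is a limit and not a number. Both measured compounds share this position: the limit of > 20000 nM in this assay, at which 2 of the 2 values shown sit. Compound 3 `CN1C/C(=C\c2cccc([N+](=O)[O-])c2)C(=O)/C(=C/c2ccc(Cl)c(Cl)c2)C1` makes one structural change: 3,4-dichlorophenyl in place of 4-bromophenyl on a double-bonded chain carbon bound to a double-bonded ring carbon. Within the data shown here, the only measured step that bears on this is a step that the two limits leave unreadable from compound 1 to compound 2, and it offers no size to carry forward. No step beyond the scatter is therefore expected in this assay, and another limit is the likeliest report. The estimated change is a step that the limit leaves unreadable from compound 2 to compound 3. Compound 3 is expected near 25000 nM, with an estimated range of 8000 nM to 50000 nM.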

Compound 3, half-maximal inhibitory concentration: 15500 nM
The estimate for compound 3 lay 1.6-fold (0.21 log units) above the measured number; measured number inside the range.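

With 3,4-dichlorophenyl on this double-bonded chain carbon, compound 3 gives a readable number, while the other two compounds stop at a limit: the limit of > 20000 nM in this assay, at which 2 of the 3 values shown sit. Replacing 4-bromophenyl gives an at least 1.2-fold lower number from compound 2 to compound 3 (0.11 log units; that floor lies within the scatter), and adding chloro in place of hydrogen on an aromatic carbon gives an at least 1.2-fold lower number from compound 1 to compound 3 (0.11 log units; that floor lies within the scatter). These are minimum sizes, so the true steps could be larger, but neither is yet shown to exceed the scatter.

From the compounds shown here alone, it remains open whether an amine or a carboxylic acid on this aromatic ring would give a lower number than the added chloro does.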